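The source may report more compounds than this note shows. Statements on the series, on what has been measured and on what is new or still open speak of the compounds shown alone.

Measured in an ADME assay on microsomes from liver (Homo sapiens) for metabolic stability; on this read-out higher numbers stand for a longer-lived compound and lower numbers for a shorter-lived compound:
- compound 1 `COc1cc(OCc2cccc(-c3ccc(C#N)cn3)c2)c2cc(-c3cn4nc(OC)sc4n3)oc2c1`: 1.57 h
- compound 2 `COc1cc(OCc2cccc(-c3cnc(OC)nc3)c2)c2cc(-c3cn4nc(OC)sc4n3)oc2c1`: 0.6 h
- compound 3 `COc1cc(OCc2csc(-c3ccc(C(=O)O)cc3)n2)c2cc(-c3cn4nc(OC)sc4n3)oc2c1`: > 2 h, a limit of the assay and not a number

Of the two actual numbers, compound 2 holds the lower, which leaves it at the short-lived end of this small set. The account now turns to compound 4 `COc1cc(OCc2cccc(OCc3ccccc3)c2)c2cc(-c3cn4nc(OC)sc4n3)oc2c1`, which has not yet been measured. The change is benzyloxy in place of 2-methoxypyrimidin-5-yl on an aromatic carbon, meta to a large group.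

Within the data shown here, only one measured step bears on this place, and it also exchanges the group that stands there. That step is modest: a 2.6-fold lower number from compound 1 to compound 2 (0.42 log units; beyond the scatter). On that evidence, a step of similar or smaller size is expected in this assay, perhaps slightly downward, though its direction is not firmly settled. The expected step is a 1.2-fold lower number from compound 2 to compound 4 (0.08 log units; within the scatter). Compound 4 is estimated at 0.5 h, with an expected range of 0.2 h to 1.3 h.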

Compound 4, half-life: 1.43 h
For compound 4 the middle estimate is 2.9-fold (0.46 log units) below the measured one; the measured number lies above the stated range.
By their numbers in this assay, from the lowest: compound 2; then compounds 4 and 1 (each within the scatter of the next). At a limit, above all of these: compound 3.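

In this assay, benzyloxy in place of 2-methoxypyrimidin-5-yl gives a 2.4-fold higher number from compound 2 to compound 4 (0.38 log units; beyond the scatter), so this place, which had so far shown only a downward step, can also carry a step upward. The two groups have the same count of heavy atoms, and the change swaps the ring nitrogens for carbon and an oxygen, while a 1.1-fold lower number from compound 1 to compound 4 (0.04 log units; within the scatter) leaves benzyloxy and 5-cyanopyridin-2-yl with no difference beyond the scatter, although their structures differ. Nothing at hand bears on why this exchange moves the number.

The compounds shown leave open which part of benzyloxy matters, the oxygen link or the carbon-only ring. They also leave open how an amine or a longer ether chain at this place would compare with compound 4.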